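Methoxy added to an amide series without measurable response

The source may hold more compounds than are shown below. What is called first, only, known or untested is meant among the compounds shown, and "the series" means these compounds.

Compound 3 `O=C(Nc1cccc(-c2nc3ccccc3s2)c1)c1cnccc1Cl` stands at the edge of what an ADME assay on BJ cells (Homo sapiens) for inhibition, with a stated time of 72 h (a higher number here means that more compound is needed for the effect, a lower number that less compound is needed), resolves: in this assay compound 3 gives > 25000 nM, a limit rather than a number. Its two relatives sit in the same place. Compound 1 `C=CC(=O)Nc1cccc(-c2nc3ccccc3s2)c1` gives > 25000 nM in this assay, again a limit. Compound 2 `C/C=C/C(=O)Nc1cccc(-c2nc3ccccc3s2)c1` gives > 25000 nM in this assay, also a limit. the limit of > 25000 nM in this assay, at which 3 of the 3 values shown sit, sums up the situation. The steps among these three, a step that the two limits leave unreadable from compound 1 to compound 2, a step that the two limits leave unreadable from compound 1 to compound 3 and a step that the two limits leave unreadable from compound 2 to compound 3, carry no readable size, although each exchanges the group on the carbonyl carbon.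

Compound 4 `COc1ccc(-c2nc3ccccc3s2)cc1NC(=O)c1cnccc1Cl` departs from compound 3 by methoxy in place of hydrogen on an aromatic carbon. None of the three measured steps touches this position; each varies the group on the carbonyl carbon instead, so no size can be borrowed for the new change in this assay. With three limits and no readable step, the plain expectation is that compound 4 behaves like compound 3 in this assay, and the step is estimated as a number no higher from compound 3 to compound 4 (the limit leaves the size open), that is no movement that could be discerned. Compound 4 is therefore expected to give 25000 nM in this assay, within 8000 nM to 60000 nM, most probably again reported only as a limit.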

Compound 4, half-maximal effective concentration: > 25000 nM
Compound 4 gave a limit, no number; the forecaster's own chance of this, stated with the estimate: 75%; the middle value lies on the limit itself.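

No size can be read for the step from compound 3 to compound 4, since both compounds give only a limit in this assay, and the series as a whole sits at that edge: the limit of > 25000 nM in this assay, at which 4 of the 4 values shown sit.

Still open, going by these compounds, is whether methoxy in place of hydrogen changes the response in this assay at all, and where any of the four compounds would fall as a number.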